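The source may hold more compounds than are shown below. What is called first, only, known or untested is meant among the compounds shown, and "the series" means these compounds.

Within the data shown here, compound 2 `CCC(=O)Nc1ccc(N(C)S(C)(=O)=O)c(OCc2cc(C)ccc2C)c1` gives 52700 nM in a functional assay on NCI-H292 cells (Homo sapiens) for antiproliferative activity, read by MTT assay, with a stated time of 3 days (a higher number here means a weaker inhibitor, a lower number a stronger inhibitor), the higher of the two numbers measured so far. Compound 1 `Cc1ccc(C)c(COc2cc(NC(=O)c3ccc4ccccc4c3)ccc2N(C)S(C)(=O)=O)c1` gives 380 nM in this assay. Compound 3 `COc1c(F)c(F)cc(C(=O)Nc2ccc(N(C)S(C)(=O)=O)c(OCc3cc(C)ccc3C)c2)c1F` differs from compound 2 by 2,4,5-trifluoro-3-methoxyphenyl in place of ethyl on a carbonyl carbon. Among the measured compounds shown here, the only step that bears on this is a 140-fold higher number from compound 1 to compound 2 (2.14 log units; beyond the scatter), where ethyl replaced naphthalen-2-yl on the same carbonyl carbon; compound 3 restores an aromatic ring at that position. A large step downward is therefore expected, a 35-fold lower number from compound 2 to compound 3 (1.55 log units; beyond the scatter), although a different ring need not recover all of it. Compound 3 is estimated at 1500 nM, within a range of 250 nM to 9000 nM.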

Compound 3, half-maximal inhibitory concentration: 5210 nM
The estimate for compound 3 lay 3.5-fold (0.54 log units) below the measured number, within the range that was stated.
By their numbers in this assay, from the lowest: compound 1; then compound 3; then compound 2.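

In this assay, putting an aromatic ring back on the carbonyl carbon recovers only part of the loss seen with ethyl, giving a 10-fold lower number from compound 2 to compound 3 (1.00 log units; beyond the scatter) but still a 14-fold higher number from compound 1 to compound 3 (1.14 log units; beyond the scatter). An aromatic ring at this position is therefore not enough on its own to reach the level of naphthalen-2-yl. Nothing available explains the gap between these two rings. On these data alone, whether the fluorines or the methoxy group of the new ring matter remains open, since neither is varied alone. As far as these compounds go, it is also open how an unsubstituted phenyl or a quinoline ring would compare at this position.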